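The source may hold more compounds than are shown below. What is called first, only, known or untested is meant among the compounds shown, and "the series" means these compounds.

Of the compounds shown here, three built on one shared core have been measured in a functional assay on HL-60 cells (Homo sapiens) for antiproliferative activity, with a stated time of 24 h; a higher number here means a weaker inhibitor, a lower number a stronger inhibitor. Compound 1 `NC(=O)c1c(NC(=O)c2ccccc2Cl)sc2c1CCNC2` gives 18600 nM. Compound 2 `N#Cc1ccccc1CN1CCc2c(sc(NC(=O)c3ccccc3Cl)c2C(N)=O)C1` gives 10400 nM, and the step of a 1.8-fold lower number from compound 1 to compound 2 (0.25 log units; within the scatter) lies within the scatter. Compound 3 `COc1ccccc1NC(=S)N1CCc2c(sc(NC(=O)c3ccccc3Cl)c2C(N)=O)C1` gives 40900 nM, the highest number of the three; since the step of a 2.2-fold higher number from compound 1 to compound 3 (0.34 log units; beyond the scatter) and the step of a 3.9-fold higher number from compound 2 to compound 3 (0.59 log units; beyond the scatter) are both beyond the scatter, compound 3 is the weakest inhibitor measured so far. Compound 4 `CSc1ccccc1NC(=S)N1CCc2c(sc(NC(=O)c3ccccc3Cl)c2C(N)=O)C1` has not yet been measured. It differs from compound 3 by methylsulfanyl in place of methoxy on an aromatic carbon, so that a 2-methoxyphenyl becomes a 2-(methylsulfanyl)phenyl at the far end of the group carried by the amine nitrogen in the ring. For the measured compounds named here, none of the three measured steps touches this spot: each of them swaps the whole group on that ring nitrogen, so no measured step bears directly on the change in hand. With nothing pointing either way, the expectation for compound 4 is a step of a 1.2-fold lower number from compound 3 to compound 4 (0.07 log units; within the scatter) that stays within the scatter. Compound 4 is therefore estimated at 35000 nM in this assay, with a likely range from 12000 nM to 100000 nM.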

Compound 4, half-maximal inhibitory concentration: 14600 nM
Beside the measured number, compound 4's estimate is 2.4-fold (0.38 log units) above it; low and high end bracket the measured number.
By their numbers in this assay, from the lowest: compounds 2, 4 and 1 (each within the scatter of the next); then compound 3.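

In this assay, the far end of the group on the ring nitrogen turns out to matter: a swap of methoxy for methylsulfanyl, on an aromatic carbon ortho to a large group, gives a 2.8-fold lower number from compound 3 to compound 4 (0.45 log units; beyond the scatter). This single change also removes the gap that set compound 3 apart, since a 1.3-fold lower number from compound 1 to compound 4 (0.11 log units; within the scatter) and a 1.4-fold higher number from compound 2 to compound 4 (0.15 log units; within the scatter) both stay within the scatter. Nothing available explains why this swap shifts the number.

For the compounds shown here, with only this one pair at this spot, it remains open whether other groups there, such as ethoxy, a chlorine atom or a dimethylamino group, would shift the number in the same direction. From the compounds shown here alone, it is also open whether methylsulfanyl would give a similar result on another carbon of the aromatic ring.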